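This account rests on a few compounds, and the source may have more. Where it says the series, first, only, none or still open, it means among the compounds named here.

For the measured compounds named here, only two compounds have been measured so far, compound 1 `COc1ccc(C(=O)c2cc(OC)c(OC)c(OC)c2)c(NC(=O)CO)c1` and compound 2 `C=C(c1ccc(OC)cc1NC(=O)CO)c1ccc(OC)c2c1OC(C)(C)C=C2`. In a functional assay on HeLa cells (Homo sapiens) for antiproliferative activity, read by MTT assay, with a stated time of 48 h (a higher number here means a weaker inhibitor, a lower number a stronger inhibitor), compound 1 gives 70 nM and compound 2 gives 40 nM as its reading. These two numbers lie within the usual scatter of each other, so compound 1 cannot be told apart from compound 2 on this evidence.

The next compound, compound 3 `COc1ccc(C(=O)c2cc(OC)c(OC)c(OC)c2)c(NC(=O)CN)c1`, keeps the core of compound 1 and alters a single group: amino in place of hydroxy on a saturated chain carbon bound to a carbonyl carbon with amino in place of hydroxy on a saturated chain carbon bound to a carbonyl carbon.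

Going by the values given here, no measured pair shows what this exchange does, so the data fix neither its size nor its direction. The expectation in this assay is therefore a modest one, a small move towards a weaker number, close to the scatter, starting from compound 1 at 70 nM as the anchor. The estimated shift is a 1.4-fold higher number from compound 1 to compound 3 (0.15 log units; within the scatter) and nothing larger is expected. For compound 3 the expected value is 100 nM with an estimated range of 30 nM to 350 nM in this assay.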

Compound 3, half-maximal inhibitory concentration: 130 nM
Estimate against measurement, compound 3: 1.3-fold (0.11 log units) below; the range from low to high includes it.
By their numbers in this assay, from the lowest: compounds 2, 1 and 3 (each within the scatter of the next, the first and the last beyond it).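

In this assay, for the compounds shown here, the exchange of hydroxy for amino on a saturated chain carbon bound to a carbonyl carbon gives a 1.9-fold higher number from compound 1 to compound 3 (0.27 log units; within the scatter), the first measured reading of any change at this position. The step shows that this position tolerates amino in place of hydroxy without a shift beyond the scatter, so the data do not tell the hydroxymethyl and aminomethyl forms apart here. No measurement at hand offers an explanation for the reading of this pair.

From the compounds shown here alone, whether that tolerance extends to other groups at this carbon stays open, for example a dimethylamino group, a carboxylic acid or a longer chain in place of aminomethyl. Going by these compounds, it also remains open whether the same exchange would read alike on the core of compound 2, which carries the same ((hydroxymethyl)carbonyl)amino group as compound 1, or whether the outcome depends on the rest of the molecule.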